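Adding a Second Chlorine to a Carbamate Series

This account rests on a few compounds, and the source may have more. Where it says the series, first, only, none or still open, it means among the compounds named here.

Three compounds share a common core and differ only at their two aromatic ends. In a functional assay on the whole organism for inhibition, with Mus musculus as the target, in the writhing test, with a stated time of 1 h, at a dose of 10 mg/kg by the oral route (on this read-out lower numbers stand for less inhibition and higher numbers for more inhibition at the one dose given (going by the name of the read-out)), compound 1 `NC(=O)OC(CCN1CCN(c2ccc(F)cc2)CC1)c1ccc(F)cc1` gives 52%, and compound 2 `COc1ccc(N2CCN(CCC(OC(N)=O)c3ccc(Cl)cc3)CC2)cc1` gives 51% in this assay; these two numbers lie within the scatter of each other, so no order can be read between them. Compound 3 `COc1cc(OC)cc(N2CCN(CCC(OC(N)=O)c3ccccc3)CC2)c1` gives 13% in this assay, a number far below that of compound 2 and beyond the scatter. Compound 2 thus stands among the higher numbers of the three, indistinguishable from compound 1 and clearly apart from compound 3.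

Compound 4 `COc1ccc(N2CCN(CCC(OC(N)=O)c3ccc(Cl)c(Cl)c3)CC2)cc1` has not yet been measured. It differs from compound 2 in a single place: chloro in place of hydrogen on an aromatic carbon. Among the compounds with values here, no measured pair in this small set shows this same change, so its effect cannot be read from the data. The expected step, a number 1 percentage points lower from compound 2 to compound 4 (within the scatter), is small, with no move beyond the scatter in either direction. Compound 4 is estimated to give about 50% in this assay, within a range from 25% to 75%.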

Compound 4, a percentage reported as inhibition, in the whole organism at one dose (the size of the read-out at that dose, not a potency): 61%
Compound 4: middle estimate off by 11 percentage points, on the low side, within the range that was stated.
By their numbers in this assay, from the lowest: compound 3; then compounds 2, 1 and 4 (each within the scatter of the next).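

In this assay, within the data shown here, this pair gives the first direct look at chloro in place of hydrogen on an aromatic carbon, with the 4-chlorophenyl of compound 2 becoming the 3,4-dichlorophenyl of compound 4. The change gives a number 10 percentage points higher from compound 2 to compound 4 (within the scatter), so a second chloro at this place, ortho to the first, keeps the read-out in the same band at the one dose given, and no real gain or loss can be claimed from this single step. Nothing available here explains the outcome of this change.

On these data alone, whether a smaller or different group at this same place, such as fluoro, a nitrile or an amine, would also keep the number in that band remains open. As far as these compounds go, it is also open whether the same added chloro would behave alike on the fluorinated aromatic ends of compound 1.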